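The compounds below may be only part of what the source reports. "The series", "measured", "known", "first", "only" and "open" are said of these compounds alone.

In a functional assay on MCF7 cells (Homo sapiens) for cytotoxicity, read by MTT assay, with a stated time of 2 days, tested at 0.1 uM (a lower number here means a stronger effect, a higher number a weaker effect of the compound at the concentration tested), compound 1 `CC(=O)c1cc(-c2ccccc2)cc2cc(-c3ccc(F)cc3)[nH]c12` gives 98.5%, compound 2 `COc1ccc(-c2cc(C(C)=O)c3[nH]c(-c4ccc(F)cc4)cc3c2)cc1` gives 88.4%, and compound 3 `COc1ccc(-c2cc3cc(-c4ccccc4)cc(C(C)=O)c3[nH]2)cc1` gives 87%, the lowest number of the three, though compound 2 stands within the scatter of it and only compound 1 sits beyond it. Compound 4 `COc1ccc(-c2cc(C(C)=O)c3[nH]c(-c4ccc(OC)cc4)cc3c2)cc1` differs from compound 3 by methoxy in place of hydrogen on an aromatic carbon. One measured step is the same kind of change, a number 10.1 percentage points lower from compound 1 to compound 2 (beyond the scatter); the other, a number 11.5 percentage points lower from compound 1 to compound 3 (beyond the scatter), also brought a methoxy onto the shared core. Both were modest and downward, so a modest downward step in this assay is expected for compound 4 as well. On that basis compound 4 is expected to give 79%, with a range of 68% to 92%, the estimated step being a number 8 percentage points lower from compound 3 to compound 4 (within the scatter).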

Compound 4, a percentage reported as activity, at one concentration (the size of the read-out at that concentration, not a potency): 96.5%
For compound 4 the middle estimate is 17.5 percentage points below the measured one, and the stated range ends below it.
By their numbers in this assay, from the lowest: compounds 3, 2, 4 and 1 (each within the scatter of the next, the first and the last beyond it).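

In this assay methoxy in place of hydrogen, para to a large group, gives a number 9.5 percentage points higher from compound 3 to compound 4 (within the scatter) and so does not repeat on this core what the same change did on the core of compound 1: the same change on two cores in this assay, a number 10.1 percentage points lower (beyond the scatter) from compound 1 to compound 2 and a number 9.5 percentage points higher (within the scatter) from compound 3 to compound 4, 19.6 percentage points apart, beyond the scatter of two such steps. Methoxy in place of fluoro gives a number 8.1 percentage points higher from compound 2 to compound 4 (within the scatter) and also reads differently on the two cores: the same change on two cores in this assay, a number 11.5 percentage points lower (beyond the scatter) from compound 1 to compound 3 and a number 8.1 percentage points higher (within the scatter) from compound 2 to compound 4, 19.6 percentage points apart, beyond the scatter of two such steps. With both new steps within the scatter, compound 4 cannot be told apart from compound 3 or compound 2 here. From the compounds shown here alone, whether an amine, a hydroxyl or a carboxylic acid at this position would shift the number stays open.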